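Removing One Methoxy Group: One Step Seen, One Expected

The compounds below may be only part of what the source reports. "The series", "measured", "known", "first", "only" and "open" are said of these compounds alone.

In a functional assay on HOP-62 cells (Homo sapiens) for cytotoxicity, read by sulforhodamine B assay, with a stated time of 48 h, tested at 0.1 uM (a higher number here means a weaker effect of the compound at the concentration tested, a lower number a stronger effect), three compounds have been measured so far. Compound 1 `COc1cc(-c2cc(/C=C/C(=O)c3ccc(N)cc3)[nH]n2)cc(OC)c1OC` gives 92%, compound 2 `COc1ccc(-c2cc(/C=C/C(=O)c3ccc(N)cc3)[nH]n2)cc1OC` gives 91%, and compound 3 `COc1cc(C(=O)/C=C/c2cc(-c3cc(OC)c(OC)c(OC)c3)n[nH]2)cc(OC)c1OC` gives 94%. All three numbers lie within the usual scatter of one another, so none of them can be called stronger or weaker than the others. Compound 3 and compound 1 carry different cores; the difference between the two cores is not broken down here.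

The change from compound 1 to compound 2 is hydrogen in place of methoxy on an aromatic carbon, and in this assay it gave a number 1 percentage points lower from compound 1 to compound 2 (within the scatter). Compound 4 `COc1ccc(-c2cc(/C=C/C(=O)c3cc(OC)c(OC)c(OC)c3)[nH]n2)cc1OC` has not yet been tested. It arises from compound 3 by the same kind of change, (hydrogen in place of methoxy on an aromatic carbon), described at a place that reads word for word like the earlier one.

Among the measured compounds shown here, for compound 4 the expected step is a number 1 percentage points lower from compound 3 to compound 4 (within the scatter), because the one measured example of this change gave a number 1 percentage points lower from compound 1 to compound 2 (within the scatter). Accordingly, compound 4 is estimated at 93%, with a likely range from 84% to 100%.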

Compound 4, a percentage reported as activity, at one concentration (the size of the read-out at that concentration, not a potency): 80%
For compound 4 the middle estimate is 13 percentage points above the measured one, and the stated range ends above it.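

In this assay, replacing the methoxy group with hydrogen gave a number 14 percentage points lower from compound 3 to compound 4 (beyond the scatter), so on this core the change goes with a stronger effect at the concentration tested. Set beside the earlier case, the two steps cannot be told apart: the same change on two cores in this assay, a number 1 percentage points lower (within the scatter) from compound 1 to compound 2 and a number 14 percentage points lower (beyond the scatter) from compound 3 to compound 4, 13 percentage points apart, within the scatter of two such steps Thus nothing here shows that the core alters what this change does, but two pairs cannot prove that the change carries over unchanged either, and a reading at one concentration gives the size of the effect, not a potency.

The compounds shown leave open whether the stronger effect in compound 4 is specific to hydrogen, since they include no other replacement, such as a hydroxyl group, a chlorine atom or a longer ether chain like ethoxy, at that place. They also leave open whether the same change would behave alike on a third core, or at other concentrations.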